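A few compounds are considered here, and "the series" means these few. Any claim that something is new, unique, unknown or untested is made for them only; others in the source may bear on it.

Of the compounds shown here, two built on the same core have been measured. Compound 1 `CC(O)(C(=O)Nc1ccc(S(=O)(=O)c2ccccc2C#N)cc1)C(F)(F)F` gives 1100 nM in a functional assay (Cavia porcellus) with sulfonylurea receptors; K-ATP channels (Homo sapiens) as the target; on this read-out higher numbers stand for weaker inhibition and lower numbers for stronger inhibition. Compound 2 `COc1cc(NC(=O)C(C)(O)C(F)(F)F)ccc1S(=O)(=O)c1ccccc1` gives 5900 nM in this assay . Compound 1 therefore stands at the lower of the two numbers, and its gap to compound 2 is larger than the usual scatter of repeated measurements, so compound 1 is the stronger inhibitor of the pair.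

Compound 3 `CC(O)(C(=O)Nc1ccc(S(=O)(=O)c2cncs2)cc1)C(F)(F)F` has not yet been measured. It differs from compound 1 in one place: 1,3-thiazol-5-yl in place of 2-cyanophenyl on a sulfonyl sulfur. Going by the values given here, no measured pair shows what such a change does on this read-out, so any expectation rests on compound 1 alone and carries wide uncertainty. The step expected here, a 2.3-fold higher number from compound 1 to compound 3 (0.36 log units; beyond the scatter), is a modest move toward a higher number, though a result within the scatter would not be surprising. Compound 3 is expected to give about 2500 nM, with a likely range from 800 nM to 8000 nM.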

Compound 3, half-maximal inhibitory concentration: 7700 nM
Compound 3: the middle estimate sits 3.1-fold (0.49 log units) below what was measured; the measured number falls inside the stated range.
By their numbers in this assay, from the lowest: compound 1; then compounds 2 and 3 (each within the scatter of the next).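

Going by these compounds alone, this is the first measured change of the group on the sulfonyl sulfur in this assay: putting 1,3-thiazol-5-yl in place of 2-cyanophenyl gives a 7.0-fold higher number from compound 1 to compound 3 (0.85 log units; beyond the scatter), a step beyond the scatter that means weaker inhibition. The group at this place therefore affects the read-out, and this exchange of rings costs inhibition rather than leaving it unchanged. Nothing measured here accounts for the loss, so its cause remains unknown.

The step changes several things at once, as the six-membered carbon ring, its nitrile and the five-membered ring with two hetero atoms all come into play, and the compounds shown do not separate these parts. Also open, going by these compounds, is whether another group on this sulfonyl sulfur, such as pyridin-3-yl or 2-aminophenyl, would match or improve on compound 1.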